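A few compounds are considered here, and "the series" means these few. Any claim that something is new, unique, unknown or untested is made for them only; others in the source may bear on it.

Measured compounds in this assay so far:

Compound 1 `C#CCSc1nnc(CCC)n1N1C(=O)c2ccccc2C1=O` gives in a functional assay on MKN-45 cells (Homo sapiens) for cytotoxicity, read by MTT assay, with a stated time of 48 h (a higher number here means a weaker inhibitor, a lower number a stronger inhibitor), a limit of > 200000 nM.
Compound 2 `CCCc1nnc(SCc2ccccc2Cl)n1N1C(=O)c2ccccc2C1=O` gives in this assay a limit of > 200000 nM.
Compound 3 `COc1cc(-c2nnc(SCc3ccccc3Cl)n2N2C(=O)c3ccccc3C2=O)cc(OC)c1OC` gives in this assay a limit of > 200000 nM.

None of the three is a number; each is a limit of the assay. Compound 4 `C#CCSc1nnc(-c2cc(OC)c(OC)c(OC)c2)n1N1C(=O)c2ccccc2C1=O` has not yet been measured in this assay. From compound 3 to compound 4 the change is ethynyl in place of 2-chlorophenyl on a saturated chain carbon bound to a sulfur. The same change, at the same place, runs from compound 2 to compound 1: ethynyl in place of 2-chlorophenyl on a saturated chain carbon bound to a sulfur, with a step that the two limits leave unreadable from compound 2 to compound 1. The two cores differ as 3,4,5-trimethoxyphenyl in place of propyl on an aromatic carbon, with a step that the two limits leave unreadable from compound 2 to compound 3. Neither step can be sized, because the limit of > 200000 nM in this assay, at which 3 of the 3 values shown sit, sets a floor under every value in the set.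

The expectation for compound 4 therefore rests on nothing more than the three limits: compound 4 is expected to return another limit, with a step that the limit leaves unreadable from compound 3 to compound 4 from compound 3 that is in truth not readable. The estimate for compound 4 is 300000 nM, with a range from 100000 nM to 1000000 nM, and it is most likely that this assay will again report only a limit for compound 4.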

Compound 4, half-maximal inhibitory concentration: > 200000 nM
Compound 4: no number, only a limit; the forecaster's own chance of this, stated with the estimate: 85%; the middle value does not contradict the limit.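

Compound 3 and compound 4 both return only a limit in this assay, so no step can be read between them, because every compound shown sits at the same limit: the limit of > 200000 nM in this assay, at which 4 of the 4 values shown sit.

The compounds shown leave open whether any compound of this series reaches a measurable value in this assay at all, and so how ethynyl compares with 2-chlorophenyl.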